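Chloro in place of methyl on the aromatic ring

A few compounds are considered here, and "the series" means these few. Any claim that something is new, unique, unknown or untested is made for them only; others in the source may bear on it.

Measured so far:
Compound 1, `CCC(C(=O)N1CCN(c2cccc(C)c2)CC1)N1C(=O)CCC1=O`: 0%
Compound 2, `CCC(C(=O)N1CCN(c2cccc(Cl)c2)CC1)N1C(=O)CCC1=O`: 50%
Compound 3, `Cc1cccc(N2CCN(C(=O)C(C)N3C(=O)CCC3=O)CC2)c1`: 0%

All three compounds were tested in a functional assay on the whole organism (strain Swiss) with Mus musculus as the target, in the maximal electroshock model, with a stated time of 0.5 h, at a dose of 100 mg/kg by the intraperitoneal route; a lower number here means a weaker effect, a higher number a stronger effect of the compound at the dose given. Compound 1 and compound 2 share the same core and differ in one place only, (chloro in place of methyl on an aromatic carbon). This single change produced a number 50 percentage points higher from compound 1 to compound 2 (beyond the scatter), a large step for a read-out of this kind.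

Compound 3 carries a different core from compound 1, and the difference between the two cores is hydrogen in place of methyl on a saturated chain carbon, two bonds along the chain from an amide-type nitrogen in a ring and a carbonyl carbon. On the read-out this change made no change at the digits printed from compound 1 to compound 3 (within the scatter), so compound 1 and compound 3 stand level with each other, and both stand well under compound 2.

Compound 4 `CC(C(=O)N1CCN(c2cccc(Cl)c2)CC1)N1C(=O)CCC1=O` has not yet been measured in this assay. It differs from compound 3 by chloro in place of methyl on an aromatic carbon, which is the same change, at the same place, that separates compound 2 from compound 1. The expectation for compound 4 therefore rests on compound 1 moving by a number 50 percentage points higher from compound 1 to compound 2 (beyond the scatter) and on compound 3 starting from 0%. Because compound 1 gives 0%, which matches the starting point of compound 3, a step of similar size is expected, although the change is made on a core that has only been seen once, so the range is kept wide. The expected step is a number 40 percentage points higher from compound 3 to compound 4 (beyond the scatter). For compound 4 the estimated result in this assay is 40%, with a range from 0% to 75%.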

Compound 4, a percentage reported as activity, at one dose (the size of the read-out at that dose, not a potency): 75%
Estimate against measurement, compound 4: 35 percentage points below; the measured number falls inside the stated range.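

In this assay, the change from 3-methylphenyl to 3-chlorophenyl gives a number 75 percentage points higher from compound 3 to compound 4 (beyond the scatter), so on this second core the change again points upward, although two pairs of compounds make no general rule and a read-out at one dose says nothing about potency. The direction carries from one core to the other, but the size of the step does not: the same change on two cores in this assay, a number 50 percentage points higher (beyond the scatter) from compound 1 to compound 2 and a number 75 percentage points higher (beyond the scatter) from compound 3 to compound 4, 25 percentage points apart, beyond the scatter of two such steps

The shorter chain tells the same story from the other side, since hydrogen in place of methyl on the saturated chain carbon gives a number 25 percentage points higher from compound 2 to compound 4 (beyond the scatter), whereas it left the pair with the methyl on the ring level, so the effects of the two changes do not simply add up, and these pairs cannot say why: the same change on two cores in this assay, no change at the digits printed (within the scatter) from compound 1 to compound 3 and a number 25 percentage points higher (beyond the scatter) from compound 2 to compound 4, 25 percentage points apart, beyond the scatter of two such steps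

The compounds shown leave open whether another group on the same aromatic carbon, such as fluoro, bromo or methoxy, would behave as chloro does. They also leave open whether a longer chain on the saturated carbon, such as propyl, would raise or lower the read-out when chloro is on the ring.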